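The compounds below may be only part of what the source reports. "The series", "measured", "known", "first", "only" and "open" are said of these compounds alone.

Working notes on the series.

Two members have been measured in an assay on isolated protein for inhibition of ubiquitin carboxyl-terminal hydrolase 7 (Homo sapiens), with stated times of 30 min and 2 h; on this read-out higher numbers stand for weaker inhibition and lower numbers for stronger inhibition. Compound 1, `Cn1nc2c(=O)n(CC3(O)CCN(Cc4ccc(-c5ccncc5)cc4Cl)CC3)cnc2c1-c1ccc(CN)cc1`, gives 257 nM in this assay. Compound 2, `Cn1nc2c(=O)n(CC3(O)CCN(Cc4ccc(-c5ccco5)cc4Cl)CC3)cnc2c1-c1ccc(Cl)cc1`, gives 143 nM in this assay. The two numbers lie within the scatter of each other, so neither compound stands apart from the other on this read-out; compound 2 is simply the one from which the next step is taken.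

Compound 3, `CCCNCc1ccc(-c2c3ncn(CC4(O)CCN(Cc5ccc(-c6ccco6)cc5Cl)CC4)c(=O)c3nn2C)cc1`, has not been measured in this assay. It differs from compound 2 in one place: (propylamino)methyl in place of chloro on an aromatic carbon. Among the measured compounds shown here, the only other guide is compound 1, which carries a different group at that same carbon and gives a number close to that of compound 2, with further differences elsewhere in the molecule.

The step from compound 2 to compound 3 is expected to be small, a 1.5-fold higher number from compound 2 to compound 3 (0.17 log units; within the scatter), in the direction of a somewhat higher number but most likely no further than the scatter. Compound 3 is therefore estimated at 210 nM in this assay, within a range of 80 nM to 550 nM.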

Compound 3, half-maximal inhibitory concentration: 43.9 nM
Estimate against measurement, compound 3: 4.8-fold (0.68 log units) above, outside the stated range (below it).
By their numbers in this assay, from the lowest: compound 3; then compounds 2 and 1 (each within the scatter of the next).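

In this assay, the change from chloro to (propylamino)methyl on this aromatic carbon gives a 3.3-fold lower number from compound 2 to compound 3 (0.51 log units; beyond the scatter), beyond the scatter. Among the compounds shown here, this is the first reading of this position with the rest of the molecule unchanged, and it shows that the larger group, with five heavy atoms against one, is compatible with stronger inhibition than chloro at this carbon. Nothing at hand accounts for the lower number.

The compounds shown leave open whether the step depends on the amine nitrogen, on the propyl chain or on both, and compound 1 cannot settle this, as it also differs elsewhere in the molecule. From the compounds shown here alone, how a hydroxymethyl group, a dimethylaminomethyl group or a longer butylaminomethyl chain would read at this carbon also remains open.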